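Aryl swap on the saturated ring: compound 3 to compound 4

This account rests on a few compounds, and the source may have more. Where it says the series, first, only, none or still open, it means among the compounds named here.

Compound 1 `CC(C)CCn1ccc(N2CCCCC2)c(C#N)c1=O` gives 185% in a functional assay on CHO cells for positive allosteric modulation of metabotropic glutamate receptor 2 (Homo sapiens), with a stated time of 30 min; on this read-out lower numbers stand for smaller maximal responses and higher numbers for larger maximal responses. Compound 2 `N#Cc1c(N2CCC(c3ccccc3F)CC2)ccn(CC2CC2)c1=O` gives 282% in this assay, and compound 3 `N#Cc1c(N2CCC(c3ccccc3Cl)CC2)ccn(CC2CC2)c1=O` gives 259% in this assay. Among the three numbers compound 3 stands second highest: compound 2 lies above it, beyond the scatter, and compound 1 lies furthest away, below it, also beyond the scatter. For the measured compounds named here, the one step that bears on the present change is a number 23 percentage points lower from compound 2 to compound 3 (beyond the scatter).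

Compound 4 `N#Cc1c(N2CCC(c3cc(F)cc(F)c3)CC2)ccn(CC2CC2)c1=O` differs from compound 3 as follows: 3,5-difluorophenyl in place of 2-chlorophenyl on a saturated ring carbon. Going by the values given here, the measured step only exchanged one halogen for another on the same aromatic carbon; no measured step tells what a change of both the halogen and its position on that ring does. The expectation for compound 4 in this assay is therefore a step of small to modest size, direction uncertain, estimated as a number 9 percentage points lower from compound 3 to compound 4 (within the scatter). Compound 4 is estimated at 250%, within 190% to 310%.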

Compound 4, largest response reached (Emax), in percent of the reference or control that the assay uses: 234%
Compound 4: the middle estimate sits 16 percentage points above what was measured, within the range that was stated.
By their numbers in this assay, from the lowest: compound 1; then compound 4; then compound 3; then compound 2.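

In this assay, 3,5-difluorophenyl in place of 2-chlorophenyl gives a number 25 percentage points lower from compound 3 to compound 4 (beyond the scatter) and in place of 2-fluorophenyl gives a number 48 percentage points lower from compound 2 to compound 4 (beyond the scatter) on this saturated ring carbon, three ring bonds from the ring nitrogen. Across these three aryl groups the maximal response therefore changes beyond the scatter not only with an exchange of halogen but also with a change of the whole halogen pattern, and 3,5-difluorophenyl gives the lowest number of the three. The number and the placement of the halogens change together in this step, and nothing on hand gives a reason for the lower numbers.

As far as these compounds go, how much of the step belongs to each of those two changes stays open. Also open, from the compounds shown here alone, is how an unsubstituted phenyl or a methoxyphenyl would compare at this carbon.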